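The source may hold more compounds than are shown below. What is called first, only, known or untested is meant among the compounds shown, and "the series" means these compounds.

Compound 1 `C=C[C@@](C)(/C=C/c1ccc(O)c(/C=C/C(=O)c2ccccc2)c1)CCC=C(C)C`: > 52000 nM, a limit.
Compound 2 `C=C[C@@](C)(/C=C/c1ccc(O)c(/C=C/C#N)c1)CCC=C(C)C`: > 52000 nM, a limit.
Compound 3 `C=C[C@@](C)(/C=C/c1ccc(O)c(/C=C/C(=O)OCc2ccccc2)c1)CCC=C(C)C`: > 52000 nM, a limit.

In a functional assay on HepG2 cells (Homo sapiens) for cytotoxicity, with a stated time of 72 h (on this read-out lower numbers stand for an effect already at smaller amounts and higher numbers for an effect only at larger amounts of compound), compound 2 gives only a limit, > 52000 nM. It shares this with compound 1 and compound 3: the limit of > 52000 nM in this assay, at which 3 of the 3 values shown sit.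

Compound 4 `C=C[C@@](C)(/C=C/c1ccc(O)c(/C=C(\C)C(=O)OCC)c1)CCC=C(C)C` departs from compound 2 as follows: 2-(ethoxycarbonyl)prop-1-en-1-yl in place of 2-cyanoethenyl on an aromatic carbon. The new group sits ortho to a hydroxy group.

The closest measured change is a step that the two limits leave unreadable from compound 2 to compound 3, which also replaces cyano, there with benzyloxycarbonyl. The other two are a step that the two limits leave unreadable from compound 1 to compound 2 and a step that the two limits leave unreadable from compound 1 to compound 3. None of the three has a readable size, so the expectation rests on all three compounds sitting at the same limit.

The expected change is a step that the limit leaves unreadable from compound 2 to compound 4, and no shift beyond the scatter is expected in either direction.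

For compound 4 the estimate is 60000 nM, with an expected range from 30000 nM to 120000 nM.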

Compound 4, half-maximal effective concentration: > 52000 nM
Compound 4: only a limit was reported (the forecaster's own chance of this, stated with the estimate: 80%); the middle value is on the limit's open side.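

In this assay compound 4 gives > 52000 nM, a limit, so the step from compound 2 to compound 4 cannot be read. The compounds shown leave open at what concentration any of them would give an effect, and whether their differing groups would change it: the limit of > 52000 nM in this assay, at which 4 of the 4 values shown sit.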